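Selenium-bearing group in place of methylsulfanyl on two cores

A few compounds are considered here, and "the series" means these few. Any claim that something is new, unique, unknown or untested is made for them only; others in the source may bear on it.

Compound 1 `CS/C(=N\C(=O)c1ccno1)NC(=O)c1ccno1`, compound 2 `CS/C(=N\C(=O)c1cc2ccccc2s1)NC(=O)c1cc2ccccc2s1` and compound 3 `O=C(/N=C(/NC(=O)c1ccno1)[Se]Cc1ccccc1)c1ccno1` have been measured in a functional assay on MCF7 cells (Homo sapiens) for cytotoxicity, read by MTT assay, with a stated time of 72 h; a lower number here means that less compound is tolerated, a higher number that more compound is tolerated; compound 4 `O=C(/N=C(/NC(=O)c1cc2ccccc2s1)[Se]Cc1ccccc1)c1cc2ccccc2s1` has not. In this assay compound 1 gives > 100000 nM, which is a limit of the assay and not a number. Compound 3 likewise gives only a limit, > 100000 nM. Going by the values given here, compound 2 gives 78500 nM, the one number among the three. The difference between the cores of compound 1 and compound 2 is not broken down here.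

From compound 1 to compound 3 the change is a group of 8 heavy atoms (7 carbon, 1 selenium; one six-membered aromatic ring of carbon only) in place of a group of 2 heavy atoms (1 carbon, 1 sulfur; no ring), on a carbon with a double bond to nitrogen. Its step, a step that the two limits leave unreadable from compound 1 to compound 3, cannot be sized because the limit of > 100000 nM in this assay, at which 2 of the 3 values shown sit, holds both ends of it.

The change from compound 2 to compound 4 is a group of 8 heavy atoms (7 carbon, 1 selenium; one six-membered aromatic ring of carbon only) in place of a group of 2 heavy atoms (1 carbon, 1 sulfur; no ring), on a carbon with a double bond to nitrogen; the surroundings of the place are the same word for word, so this is the same change, now made on the core of compound 2. Among the compounds with values here, the one measured instance of it gives no readable size, so the step from compound 2 to compound 4 in this assay is estimated as roughly flat, a 1.1-fold higher number from compound 2 to compound 4 (0.03 log units; within the scatter), with wide room on either side. On that basis compound 4 is expected near 85000 nM in this assay. The expected range for compound 4 runs from 30000 nM to 250000 nM, and a fair share of such measurements would be expected to come back as a limit only, as for compound 3.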

Compound 4, concentration lethal to 50% of the cells: 87900 nM
Compound 4: the middle estimate sits 1.0-fold (0.01 log units) below what was measured; the range from low to high includes it.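

In this assay, putting the selenium-bearing group in place of methylsulfanyl on the core of compound 2 gives a 1.1-fold higher number from compound 2 to compound 4 (0.05 log units; within the scatter), so the two values stand within the scatter of each other and this core shows no readable effect of the change. On the core of compound 1, the step to compound 3 cannot be read, because both values are limits of the assay and not numbers: the limit of > 100000 nM in this assay, at which 2 of the 4 values shown sit.

The series therefore holds one readable instance of this change, which does not show that it behaves alike on the two cores or that the flat result would carry over to a further core.

As far as these compounds go, it remains open whether the selenium atom or the six-membered aromatic ring of the entering group matters on either core, and a benzylsulfanyl group or a methylselanyl group on the same carbon would separate the two. Also open, from the compounds shown here alone, is whether an entering group bearing an amine or a carboxylic acid on that carbon would give a step beyond the scatter on the core of compound 2, where this assay has so far returned numbers rather than limits.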